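The source may report more compounds than this note shows. Statements on the series, on what has been measured and on what is new or still open speak of the compounds shown alone.

Working notes on the series.

The series rests on a shared core carrying a nitro group, shown in compound 1 `Cc1ncc([N+](=O)[O-])n1CCOc1ccccc1` and compound 2 `Cc1ncc([N+](=O)[O-])n1CCOc1ccc(Cl)c(Cl)c1`. Both were run in a functional assay on HT-29 cells (Homo sapiens) for cytotoxicity, read by MTT assay, with a stated time of 24 h; on this read-out lower numbers stand for stronger inhibition and higher numbers for weaker inhibition. Compound 1 gives 134 ug/mL in this assay, and compound 2 gives 109 ug/mL. Compound 2 shows the lower of the two numbers, but its gap to compound 1 falls within the scatter, so the two are taken as equivalent on this read-out.

Compound 3 `Cc1cc(OCCn2c([N+](=O)[O-])cnc2C)ccc1Cl` has not yet been measured in this assay. It differs from compound 2 in one place: methyl in place of chloro on an aromatic carbon. Going by the values given here, no measured pair shows this kind of exchange, so no step size is known here. Given that both measured compounds sit close together, the step in this assay from compound 2 to compound 3 is expected to be a 1.1-fold higher number from compound 2 to compound 3 (0.02 log units; within the scatter), with no change beyond the scatter in either direction. Compound 3 is accordingly estimated at 115 ug/mL in this assay, within a range of 55 ug/mL to 240 ug/mL.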

Compound 3, half-maximal inhibitory concentration: 159 ug/mL
Compound 3: the middle estimate sits 1.4-fold (0.14 log units) below what was measured, within the range that was stated.
By their numbers in this assay, from the lowest: compounds 2, 1 and 3 (each within the scatter of the next).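

Methyl in place of chloro on an aromatic carbon, ortho to a chloro group and meta to a large group, gives a 1.5-fold higher number from compound 2 to compound 3 (0.16 log units; within the scatter) in this assay and thereby supplies the first measured step for this exchange in the series. Going by these compounds alone, at this position, the read-out does not separate chloro from methyl, something the earlier compounds could not show, as neither of them formed a pair with this exchange. No measurement at hand bears on the reason for the size of this step.

Going by these compounds, it remains open whether a different group at this position, such as an amine, a carboxylic acid or a longer chain, would move the number beyond the scatter. Also open, on these data alone, is whether the same exchange at another carbon of the aromatic ring would stay within the scatter.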